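Aryl exchange on the amide nitrogen: compound 3

This account rests on a few compounds, and the source may have more. Where it says the series, first, only, none or still open, it means among the compounds named here.

Going by the values given here, in a functional assay on HEK293 cells for agonist activity at D(4) dopamine receptor (Homo sapiens), read by FLIPR (a higher number here means that more compound is needed for the effect, a lower number that less compound is needed), compound 2 `O=C(CN1CCC(c2cccc[n+]2[O-])CC1)Nc1ccc(F)cc1` gives 85 nM; compound 1 `O=C(CN1CCC(c2cccc[n+]2[O-])CC1)Nc1cc(Cl)cc(Cl)c1` gives 160 nM, and the two stand inside one scatter band, the only step so far being a 1.9-fold lower number from compound 1 to compound 2 (0.27 log units; within the scatter). Compound 3 `Cc1cccc(C)c1NC(=O)CN1CCC(c2cccc[n+]2[O-])CC1` differs from compound 2 by 2,6-dimethylphenyl in place of 4-fluorophenyl on an amide-type nitrogen. Among the compounds with values here, the one comparable step, an aryl exchange at the same amide nitrogen, was flat, so for compound 3 a step of about a 1.4-fold higher number from compound 2 to compound 3 (0.15 log units; within the scatter) is expected, not beyond the scatter in either direction. Compound 3 is therefore estimated at 120 nM, with a range of 40 nM to 400 nM.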

Compound 3, half-maximal effective concentration: 346 nM
Compound 3: the middle estimate sits 2.9-fold (0.46 log units) below what was measured, within the range that was stated.
By their numbers in this assay, from the lowest: compounds 2 and 1 (each within the scatter of the next); then compound 3.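

At this amide-type nitrogen the choice of aryl group can move the number in this assay beyond the scatter: 2,6-dimethylphenyl gives a 4.1-fold higher number from compound 2 to compound 3 (0.61 log units; beyond the scatter) and also a 2.2-fold higher number from compound 1 to compound 3 (0.33 log units; beyond the scatter), whereas the earlier exchange stayed within it. Both new steps are modest, and compound 3 now stands apart from the other two compounds, which remain within one scatter band. Nothing available here explains this shift.

Still open, from the compounds shown here alone, is whether both methyl groups are needed for the shift, which an unsubstituted phenyl or a phenyl carrying a single methyl would help to settle. Also open, going by these compounds, is how a non-aromatic group such as cyclohexyl would read at this nitrogen.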